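A Second Bromine in a Sulfonyl Hydrazide Series

A few compounds are considered here, and "the series" means these few. Any claim that something is new, unique, unknown or untested is made for them only; others in the source may bear on it.

Compound 1 `CC(=O)Nc1ccc(S(=O)(=O)NNc2ccc(F)cc2)cc1` was measured in an assay for inhibition of Indoleamine 2,3-dioxygenase 1 (Homo sapiens), read by spectrophotometry, with stated times of 1 h and 4 h (a higher number here means a weaker inhibitor, a lower number a stronger inhibitor), and gave 79 nM. Compound 2 `CC(=O)Nc1ccc(S(=O)(=O)NNc2ccc(F)c(Br)c2)cc1` differs from it in one place: bromo in place of hydrogen on an aromatic carbon. In this assay compound 2 gives 128 nM, and the step is a 1.6-fold higher number from compound 1 to compound 2 (0.21 log units; within the scatter). Compound 3 `O=S(=O)(NNc1ccc(Br)cc1)c1ccccc1` rests on a different core, and the difference between the two cores is not broken down here. In this assay compound 3 gives 172 nM, the highest of the three numbers, within the scatter of compound 2 and beyond the scatter of compound 1.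

Compound 4 `O=S(=O)(NNc1ccc(Br)cc1)c1ccc(Br)cc1` has not yet been measured. It differs from compound 3 by bromo in place of hydrogen on an aromatic carbon. This is the same kind of change as that from compound 1 to compound 2, though not the same: in compound 2 the bromo sits ortho to a fluoro group and meta to a large group, whereas in compound 4 it sits para to a large group. Going by the values given here, the only precedent within these compounds is the step of a 1.6-fold higher number from compound 1 to compound 2 (0.21 log units; within the scatter), which stayed within the scatter. Because the step of a 1.6-fold higher number from compound 1 to compound 2 (0.21 log units; within the scatter) was that small, the expected step here is also small, a 1.3-fold higher number from compound 3 to compound 4 (0.11 log units; within the scatter). In this assay compound 4 is therefore estimated at 220 nM, with the likely range running from 110 nM to 450 nM.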

Compound 4, half-maximal inhibitory concentration: 85 nM
Compound 4: the middle estimate sits 2.6-fold (0.41 log units) above what was measured; measured number below the stated range.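

In this assay, putting a bromo in place of hydrogen on an aromatic carbon of the core of compound 3 gives a 2.0-fold lower number from compound 3 to compound 4 (0.31 log units; beyond the scatter), so here the change goes with a stronger inhibitor, and the step is a modest one. On the core of compound 1, the same kind of change gave a 1.6-fold higher number from compound 1 to compound 2 (0.21 log units; within the scatter), so a step seen on one core in this series cannot simply be carried over to the other, and the two results differ by more than the scatter of two such steps allows: the same change on two cores in this assay, a 1.6-fold higher number (0.21 log units; within the scatter) from compound 1 to compound 2 and a 2.0-fold lower number (0.31 log units; beyond the scatter) from compound 3 to compound 4, 3.3-fold (0.52 log units) apart, beyond the scatter of two such steps What this does not show is the reason for the difference, since the two steps differ in the core and also in where the bromo sits, which in compound 4 is para to a large group, and a single pair on each core cannot separate these two things.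

The compounds shown leave open whether a chloro or a methoxy group in that same place on the core of compound 3 would go with a step like the one to compound 4. They also leave open whether a bromo in one and the same place on both cores would give steps that agree, and how the change would behave on a third core, such as one carrying an amine.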